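Trimming a Phenyl to a Methyl on the Chain

The compounds below may be only part of what the source reports. "The series", "measured", "known", "first", "only" and "open" are said of these compounds alone.

Measured so far:
compound 1 `CN1/C(=C/C=C/C2=[N+](CCCc3ccccc3)c3ccccc3C2(C)C)C(C)(C)c2ccccc21` — 35%
compound 2 `CCCCN1/C(=C/C=C/C2=[N+](CCCC)c3ccc(Br)cc3C2(C)C)C(C)(C)c2cc(Br)ccc21` — 48%

In an assay for displacement of a labelled ligand from protein arginine N-methyltransferase 1 (Homo sapiens), read by scintillation proximity assay, with stated times of 5 min and 8 min, tested at 10 uM (on this read-out lower numbers stand for a weaker effect and higher numbers for a stronger effect at the one concentration tested), compound 1 gives 35%, the lower of the two numbers measured. Compound 2 gives 48% in the same assay, a number beyond the usual scatter above that of compound 1; since the two compounds differ in several places at once, only the two values themselves can be compared, with no single change to credit for the gap.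

Compound 3 `CCCC[N+]1=C(/C=C/C=C2/N(C)c3ccccc3C2(C)C)C(C)(C)c2ccccc21` has not yet been measured. It differs from compound 1 in one place, (methyl in place of phenyl on a saturated chain carbon, three bonds along the chain from a double-bonded nitrogen in a ring). Among the measured compounds shown here, nothing measured so far tracks this change alone, so the expected step in this assay is small, a modest rise at most and possibly none beyond the scatter. Compound 2, which carries the shorter chain along with other differences, sits somewhat higher, which leans the expectation upward rather than downward. Compound 3 is therefore expected to give 40%, within a range from 25% to 55%. This amounts to an expected step of a number 5 percentage points higher from compound 1 to compound 3 (within the scatter).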

Compound 3, a percentage reported as inhibition, at one concentration (the size of the read-out at that concentration, not a potency): 8%
For compound 3 the middle estimate is 32 percentage points above the measured one; measured number below the stated range.
By their numbers in this assay, from the lowest: compound 3; then compound 1; then compound 2.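

In this assay, putting methyl in place of phenyl on a saturated chain carbon, three bonds along the chain from a double-bonded nitrogen in a ring, gives a number 27 percentage points lower from compound 1 to compound 3 (beyond the scatter). Among the compounds shown here, this is the first comparison here that isolates a single place on the shared core, and it shows that the read-out depends on how this chain ends: read one bond further out, the change is 3-phenylpropyl to butyl, and the shorter, ring-free group goes with the weaker effect at the one concentration tested. Nothing available here explains why the number falls.

The step alone cannot separate the role of the aromatic ring from that of the size of the group, so a cyclohexyl or a pyridyl ring at the end of the same chain, or a longer chain ending in methyl, would be needed to tell these apart. Whether the same trim would have a similar effect with the bromine atoms of compound 2 on the core also stays open, as does how strong the effect of any of these compounds would be at other concentrations.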